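The source may hold more compounds than are shown below. What is called first, only, known or untested is meant among the compounds shown, and "the series" means these compounds.

Working notes on the series. The shared core is carried by compound 1 `Nc1ccc(S(=O)(=O)N2CCN(c3ncc(C(O)(C(F)(F)F)C(F)(F)F)cc3C3CC3)CC2)cn1`, compound 2 `Nc1ccc(S(=O)(=O)N2CCN(c3ncc(C(O)(C(F)(F)F)C(F)(F)F)cc3C#CC3CC3)CC2)cn1` and compound 3 `CC(C)(O)C#Cc1cc(C(O)(C(F)(F)F)C(F)(F)F)cnc1N1CCN(S(=O)(=O)c2ccc(N)nc2)CC1`; compound 4 `Nc1ccc(S(=O)(=O)N2CCN(c3ncc(C(O)(C(F)(F)F)C(F)(F)F)cc3-c3cccnc3)CC2)cn1` has not yet been run. In an ADME assay (liver) for metabolic stability, with Liver microsome (Homo sapiens) as the target, using microsomes and NADPH, with a stated time of 30 min, tested at 1 uM (a higher number here means faster removal of the compound, a lower number slower removal), compound 1 gives 38 mL.min-1.g-1. Compound 2 returns only a limit of the assay in this assay, < 14 mL.min-1.g-1. Compound 3 likewise sits at a limit of the assay in this assay, < 14 mL.min-1.g-1. The steps of an at least 2.7-fold lower number from compound 1 to compound 2 (0.43 log units; beyond the scatter) and an at least 2.7-fold lower number from compound 1 to compound 3 (0.43 log units; beyond the scatter) can therefore be read only as bounds, and a step that the two limits leave unreadable from compound 2 to compound 3 cannot be read at all, since (the limit of < 14 mL.min-1.g-1 in this assay, at which 2 of the 3 values shown sit). Compound 3 thus stands at the low end of the values shown, on a limit rather than a number.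

The change to compound 4 is pyridin-3-yl in place of 3-hydroxy-3-methylbut-1-yn-1-yl on an aromatic carbon. Among the compounds with values here, no measured step covers a pyridin-3-yl; the two steps that bear on the position, an at least 2.7-fold lower number from compound 1 to compound 2 (0.43 log units; beyond the scatter) and an at least 2.7-fold lower number from compound 1 to compound 3 (0.43 log units; beyond the scatter), show only that both 2-cyclopropylethynyl and 3-hydroxy-3-methylbut-1-yn-1-yl give lower numbers than the cyclopropyl of compound 1. A return toward the value of compound 1 is expected but not assured, and the expected step is an at least 1.5-fold higher number from compound 3 to compound 4 (0.19 log units; that floor lies within the scatter). For compound 4 the estimate in this assay is 22 mL.min-1.g-1, with a range from 10 mL.min-1.g-1 to 48 mL.min-1.g-1.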

Compound 4, intrinsic clearance in microsomes: 17 mL.min-1.g-1
Compound 4: middle estimate off by 1.3-fold (0.11 log units), on the high side; the range from low to high includes it.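

In this assay compound 4 puts a six-membered aromatic ring at this position and gives a number rather than a limit, which is more than either group with a triple bond allowed. The comparison with cyclopropyl can now be sized: a 2.2-fold lower number from compound 1 to compound 4 (0.35 log units; beyond the scatter). Together with the bounds from the earlier compounds, this means that the lower number relative to cyclopropyl is not confined to groups with a triple bond, and no compound shown here goes against that, while the comparisons with those two groups give only floors, an at least 1.2-fold higher number from compound 3 to compound 4 (0.08 log units; that floor lies within the scatter) and an at least 1.2-fold higher number from compound 2 to compound 4 (0.08 log units; that floor lies within the scatter), neither of which separates pyridin-3-yl from them because both start from a limit: the limit of < 14 mL.min-1.g-1 in this assay, at which 2 of the 4 values shown sit.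

Whether the ring nitrogen of pyridin-3-yl contributes, or the aromatic ring alone accounts for the step from cyclopropyl, stays open, and a phenyl group at the same place would separate the two. From the compounds shown here alone, the values of compound 2 and compound 3 are limits, so the order of the three groups that lower the number also stays open.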